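Chloro in Place of Nitro, Measured Once, Expected Again

The source may report more compounds than this note shows. Statements on the series, on what has been measured and on what is new or still open speak of the compounds shown alone.

compound 1, `O=C(/C=C/c1ccc(Cl)cc1)Nc1nc2ccc(Cl)cc2s1`: 204 umol/kg
compound 2, `CC(=O)N1N=C(Nc2nc3ccc([N+](=O)[O-])cc3s2)CC1c1ccc(O)cc1`: 162 umol/kg
compound 3, `O=C(/C=C/c1ccc(Cl)cc1)Nc1nc2ccc([N+](=O)[O-])cc2s1`: 259 umol/kg

Of the compounds shown here, three have been tested in a functional assay on the whole organism (Hindlimb, strain albino) with Mus musculus as the target, in the maximal electroshock model, with a stated time of 0.5 h; a higher number here means that more compound is needed for the effect, a lower number that less compound is needed. Compound 3 and compound 1 differ in one place, (chloro in place of nitro on an aromatic carbon), and the resulting step is a 1.3-fold lower number from compound 3 to compound 1 (0.10 log units; within the scatter). Compound 2 carries a different core; the difference between the two cores is not broken down here, and its value sits within the scatter of the other two, so no order among the three is claimed.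

Compound 4, `CC(=O)N1N=C(Nc2nc3ccc(Cl)cc3s2)CC1c1ccc(O)cc1`, has not been measured. It differs from compound 2 by chloro in place of nitro on an aromatic carbon, the same change as that made from compound 3 to compound 1. Because a 1.3-fold lower number from compound 3 to compound 1 (0.10 log units; within the scatter) was within the scatter, a similar step of a 1.2-fold lower number from compound 2 to compound 4 (0.06 log units; within the scatter) is expected here. Compound 4 is therefore estimated to give 140 umol/kg in this assay, with a range from 65 umol/kg to 300 umol/kg.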

Compound 4, dose for half-maximal effect: 106 umol/kg
Compound 4: middle estimate off by 1.3-fold (0.12 log units), on the high side; the measured number falls inside the stated range.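

In this assay, chloro in place of nitro on an aromatic carbon gives a 1.5-fold lower number from compound 2 to compound 4 (0.18 log units; within the scatter), and this step agrees with the earlier one: the same change on two cores in this assay, a 1.3-fold lower number (0.10 log units; within the scatter) from compound 3 to compound 1 and a 1.5-fold lower number (0.18 log units; within the scatter) from compound 2 to compound 4, 1.2-fold (0.08 log units) apart, within the scatter of two such steps. On these two cores, then, the change carries over, and its effect stays within the scatter on both. This does not show that chloro and nitro differ in this assay, and two cores give no grounds for a rule that reaches a third.

The compounds shown leave open whether another group on that aromatic carbon, such as an amine, a carboxylic acid or a methoxy group, would give a step beyond the scatter. They also leave open how this change behaves on any other core.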